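A few compounds are considered here, and "the series" means these few. Any claim that something is new, unique, unknown or untested is made for them only; others in the source may bear on it.

Measured in an ADME assay on Vero cells (Chlorocebus sabaeus) for inhibition; on this read-out higher numbers stand for lower toxicity in this test and lower numbers for higher toxicity in this test:
- compound 1 `O=C1/C(=C/c2cccc(Br)c2)CCC/C1=C\c1cccc(Br)c1`: 35900 nM
- compound 2 `COc1ccc(/C=C2\CCC/C(=C\c3ccccc3F)C2=O)cc1`: 270000 nM

Compound 2 stands highest of the two, and the gap down to compound 1 lies beyond the scatter. Compound 3 `COc1ccc(/C=C2\CCC/C(=C\c3cccc(Br)c3)C2=O)cc1` has not yet been measured. Its difference from compound 2 is 3-bromophenyl in place of 2-fluorophenyl on a double-bonded chain carbon bound to a double-bonded ring carbon. Among the measured compounds shown here, no step between measured compounds isolates this change, so the estimate rests on thin evidence. For the measured compounds named here, the only guide is that 3-bromophenyl also occurs in compound 1, which gives 35900 nM. A downward step in this assay is therefore expected, towards higher toxicity in this test. The estimated change is a 2.8-fold lower number from compound 2 to compound 3 (0.45 log units; beyond the scatter), a drop expected to lie beyond the scatter. Compound 3 is estimated at 95000 nM, with an expected range of 35000 nM to 250000 nM.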

Compound 3, half-maximal cytotoxic concentration: 30000 nM
Compound 3: middle estimate off by 3.2-fold (0.50 log units), on the high side; measured number outside the range, below it.
By their numbers in this assay, from the lowest: compounds 3 and 1 (each within the scatter of the next); then compound 2.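

In this assay the position on a double-bonded chain carbon bound to a double-bonded ring carbon now has a step of its own: 3-bromophenyl in place of 2-fluorophenyl gives (a 9.0-fold lower number from compound 2 to compound 3 (0.95 log units; beyond the scatter)), a move towards higher toxicity in this test. The second step shows no such effect, since 4-methoxyphenyl in place of 3-bromophenyl gives (a 1.2-fold lower number from compound 1 to compound 3 (0.08 log units; within the scatter)), which leaves compound 1 and compound 3 indistinguishable in this test. No measurement on hand accounts for either step.

Among the compounds shown here, whether the drop follows the bromine or the different ring position of the halogen stays open, as the single step changes both at once. As far as these compounds go, how a phenyl group carrying an amine or a carboxylic acid would read at this position also stays open.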